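The source may hold more compounds than are shown below. What is called first, only, known or untested is meant among the compounds shown, and "the series" means these compounds.

Compound 1, `CC(C)N1CCC(Oc2ccc(C(=O)Nc3ccc(NC(=O)Nc4cc(C(C)(C)C)on4)cc3)nc2)CC1`: in an in vivo ADME assay on the whole organism (plasma, strain Sprague-Dawley) for pharmacokinetics, with Rattus norvegicus as the target, read by LC-MS (on this read-out higher numbers stand for fast clearance and lower numbers for slow clearance), compound 1 gives 16 mL/min/kg.
Compound 2, `CC(C)(C)c1cc(NC(=O)Nc2ccc(NC(=O)c3cc(OC4CCNCC4)ccn3)cc2)no1`: in this assay compound 2 gives 35.8 mL/min/kg.

Of the compounds shown here, two have a number in this assay so far, and compound 2 stands at the top of them: its clearance is the higher of the two, and the gap to compound 1 lies beyond the usual scatter of repeated measurements. Compound 3, `Cc1ccnc(C(=O)Nc2ccc(NC(=O)Nc3cc(C(C)(C)C)on3)cc2)c1`, has not yet been measured. Compared with compound 2 it carries a single change, (methyl in place of (piperidin-4-yl)oxy on an aromatic carbon). Going by the values given here, no measured pair in this set shows the same change, so there is no step to lean on; the only guide is that compound 1 and compound 2, which differ in this very region of the core, sit apart from each other in this assay. The author therefore expects only a small downward movement, a 1.5-fold lower number from compound 2 to compound 3 (0.17 log units; within the scatter), a step that would not go beyond the scatter. On that basis the clearance of compound 3 in this assay is estimated at 24 mL/min/kg, with a plausible range from 10 mL/min/kg to 55 mL/min/kg.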

Compound 3, clearance: 37.9 mL/min/kg
Estimate against measurement, compound 3: 1.6-fold (0.20 log units) below; low and high end bracket the measured number.
By their numbers in this assay, from the lowest: compound 1; then compounds 2 and 3 (each within the scatter of the next).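

In this assay the change from (piperidin-4-yl)oxy to methyl, on the aromatic carbon opposite the ring nitrogen, gives a 1.1-fold higher number from compound 2 to compound 3 (0.02 log units; within the scatter), so this first single-place step in the set cannot be told apart from repeat measurement. The group that leaves has 7 heavy atoms, a six-membered non-aromatic ring, a hydrogen-bond donor and hydrogen-bond acceptors, whereas the methyl that enters has 1 heavy atom and none of these, and for this one pair that large difference in the substituent leaves no mark on the clearance read-out. No measurement in hand bears on why the two compounds read alike.

Going by these compounds, whether this holds for the position in general stays open, since a single pair cannot show if other groups in the same place, such as a primary amine, a carboxylic acid or a longer alkyl chain, would also leave clearance unmoved. On these data alone, it is equally open whether the same exchange would give so small a step on the core of compound 1.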